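Swapping a Halogen for Methyl on the Fused Ring

A few compounds are considered here, and "the series" means these few. Any claim that something is new, unique, unknown or untested is made for them only; others in the source may bear on it.

Compound 2 `CC#C[C@@H](CC(=O)O)c1ccc(OC[C@H]2COc3ccc(Br)cc3O2)cc1` and compound 1 `CC#C[C@@H](CC(=O)O)c1ccc(OC[C@H]2COc3ccc(F)cc3O2)cc1` share a core and differ only in the substituent on the fused ring. In a functional assay on HEK293 cells for agonist activity at Free fatty acid receptor 1 (Homo sapiens), read by fluorescence and calcium flux, with a stated time of 10 min (on this read-out lower numbers stand for an effect already at smaller amounts and higher numbers for an effect only at larger amounts of compound), compound 1 gives 210 nM. In this assay compound 2 gives 210 nM, so compound 2 stands level with compound 1, and the step of no change at the digits printed from compound 1 to compound 2 (within the scatter) lies within the scatter. The next compound, compound 3 `CC#C[C@@H](CC(=O)O)c1ccc(OC[C@H]2COc3ccc(C)cc3O2)cc1`, carries methyl in place of bromo on an aromatic carbon. Within the data shown here, only one measured step bears on this position, the exchange of one substituent for another at the same aromatic carbon, and it left the potency unchanged. A methyl in that place is therefore expected to behave much like the two halogens, giving a step of no change at the digits printed from compound 2 to compound 3 (within the scatter) that stays within the scatter. Compound 3 is estimated at 210 nM, with a range from 90 nM to 500 nM.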

Compound 3, half-maximal effective concentration: 120 nM
Beside the measured number, compound 3's estimate is 1.8-fold (0.24 log units) above it; measured number inside the range.
By their numbers in this assay, from the lowest: compounds 3, 1 and 2 (each within the scatter of the next).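

In this assay the exchange of bromo for methyl gives a 1.8-fold lower number from compound 2 to compound 3 (0.24 log units; within the scatter), and the exchange of fluoro for methyl gives a 1.8-fold lower number from compound 1 to compound 3 (0.24 log units; within the scatter). The earlier pair showed only that one halogen can stand in for another at this aromatic carbon; these steps show that the same holds for a methyl, since compound 3 stays within the scatter of both halogen compounds. Nothing available here accounts for this tolerance at the position.

The compounds shown leave open whether an amine, a methoxy group or a trifluoromethyl group at this carbon would also stay within the scatter of these three. They also leave open whether a longer chain, such as ethyl or propyl, would do the same.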